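The source may hold more compounds than are shown below. What is called first, only, known or untested is meant among the compounds shown, and "the series" means these compounds.

Three compounds of this series carry numbers in an ADME assay on A549 cells (Homo sapiens) for cytotoxicity, read by MTT assay, tested at 100 uM; on this read-out higher numbers stand for a weaker effect at the one concentration tested and lower numbers for a stronger effect. Compound 1 `COc1ccc(C2CNC(=O)NC2)cc1O[C@@H]1C[C@H]2CC[C@H]1C2` gives 43.3%, compound 2 `C#CCSc1nsc(NC(=O)Nc2ccccc2Cl)n1` gives 21.4%, and compound 3 `O=C(Nc1nc(SCCOc2ccccc2)ns1)Nc1ccc(F)cc1F` gives 27.3%. Compound 3 stands second highest of the three; its number lies within the scatter of compound 2 and beyond the scatter of compound 1, whose number is the higher one. Compound 4 `C=CCSc1nsc(NC(=O)Nc2ccc(F)cc2F)n1` is not yet measured and differs from compound 3 by vinyl in place of phenoxymethyl on a saturated chain carbon bound to a sulfur. Going by the values given here, no step between measured compounds sizes a change of this kind, and the two compounds bearing a chain on the sulfur, compound 2 and compound 3, sit close together in this assay. Expected is a step of a number 2.3 percentage points lower from compound 3 to compound 4 (within the scatter), within the scatter. Compound 4 is estimated at 25%, with a range from 12% to 40%.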

Compound 4, a percentage reported as activity, at one concentration (the size of the read-out at that concentration, not a potency): 31.3%
Compound 4: the middle estimate sits 6.3 percentage points below what was measured; the measured number falls inside the stated range.
By their numbers in this assay, from the lowest: compounds 2, 3 and 4 (each within the scatter of the next); then compound 1.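

In this assay, the step at this position, on a saturated chain carbon bound to a sulfur, is a number 4 percentage points higher from compound 3 to compound 4 (within the scatter). 2-phenoxyethyl and allyl therefore cannot be told apart at the one concentration tested, and the aromatic ring of phenoxymethyl is not required for a number in this range. Nothing measured on these compounds accounts for the step.

Open, going by these compounds, is whether an amine or a carboxylic acid on this chain would stay within the scatter of these two compounds. On these data alone, a longer unbranched alkyl chain in the same place is equally open.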